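Compound 3: cyclohexyl gives way on the shared core

The compounds below may be only part of what the source reports. "The series", "measured", "known", "first", "only" and "open" are said of these compounds alone.

Measured in an ADME assay on MT4 cells (Homo sapiens) for cytotoxicity, read by MTT assay, with a stated time of 5 days; a higher number here means that more compound is tolerated, a lower number that less compound is tolerated:
Compound 1 `CCC(CC)Nc1cc(Oc2c(OC)cc3cc(C#N)ccc3c2OC)nc(Nc2ccc(C#N)cc2)n1`: > 125000 nM, a limit.
Compound 2 `COc1cc2cc(C#N)ccc2c(OC)c1Oc1cc(NC2CCCCC2)nc(Nc2ccc(C#N)cc2)n1`: > 125000 nM, a limit.

Compound 2 stands only at a limit, and no number is known for it. The evidence so far is the limit of > 125000 nM in this assay, at which 2 of the 2 values shown sit. Compound 3 `COc1cc2cc(C#N)ccc2c(OC)c1Oc1cc(NCCC2=CCCCC2)nc(Nc2ccc(C#N)cc2)n1` brings this change: 2-(cyclohex-1-en-1-yl)ethyl in place of cyclohexyl on a nitrogen on an aromatic ring. Within the data shown here, the only measured step, a step that the two limits leave unreadable from compound 1 to compound 2, has no readable size and gives no direction. In this assay, no change beyond the scatter is therefore expected. The expected step is an at least 1.2-fold lower number from compound 2 to compound 3 (0.09 log units; that floor lies within the scatter). Compound 3 is estimated at 100000 nM, with an expected range from 30000 nM to 125000 nM.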

Compound 3, half-maximal cytotoxic concentration: > 125000 nM
Compound 3: no number, only a limit; the forecaster's own chance of this, stated with the estimate: 60%; at least 1.2-fold (0.09 log units) between middle value and limit.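

Among these compounds, compound 1, compound 2 and compound 3 all stand only at a limit in this assay, and no step among them can be read. As far as these compounds go, whether pentan-3-yl, cyclohexyl and 2-(cyclohex-1-en-1-yl)ethyl differ at all in this assay stays open.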